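A few compounds are considered here, and "the series" means these few. Any claim that something is new, unique, unknown or untested is made for them only; others in the source may bear on it.

Values measured so far in a functional assay on K562 cells (Homo sapiens) for cytotoxicity, read by trypan blue exclusion, with a stated time of 96 h; a higher number here means a weaker inhibitor, a lower number a stronger inhibitor

Compound 1 `COc1ccc(CS(=O)(=O)/C=C/c2c(OC)cccc2OC)cc1[N+](=O)[O-]` gives 20000 nM
Compound 2 `COc1cc(OC)c(/C=C/S(=O)(=O)Cc2ccc(OC)c([N+](=O)[O-])c2)c(OC)c1` gives 2500 nM
Compound 3 `COc1cc(OC)c(/C=C/S(=O)(=O)Cc2ccc(F)c([N+](=O)[O-])c2)c(OC)c1` gives 25000 nM

Compound 2 has the lowest number of the three. Compound 4 `COC(=O)[C@H](C)Nc1cc(CS(=O)(=O)/C=C/c2c(OC)cc(OC)cc2OC)ccc1OC` carries (1-(methoxycarbonyl)ethyl)amino in place of nitro on an aromatic carbon. Two measured steps offer a guide, though neither replaces the nitro. Methoxy in place of hydrogen gave an 8.0-fold lower number from compound 1 to compound 2 (0.90 log units; beyond the scatter) and fluoro in place of methoxy gave a 10-fold higher number from compound 2 to compound 3 (1.00 log units; beyond the scatter) (both modest). A step of similar modest size is therefore expected in this assay (the direction is not settled by these data, and a lower number is only slightly favoured). The estimated change is a 5.0-fold lower number from compound 2 to compound 4 (0.70 log units; beyond the scatter) (an expectation only). Compound 4 is estimated at 500 nM (expected range 50 nM to 5000 nM).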

Compound 4, half-maximal inhibitory concentration: 200 nM
Compound 4: the middle estimate sits 2.5-fold (0.40 log units) above what was measured; the range from low to high includes it.
By their numbers in this assay, from the lowest: compound 4; then compound 2; then compounds 1 and 3 (each within the scatter of the next).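

In this assay, within the data shown here, all the earlier compounds kept the nitro on this aromatic carbon, ortho to a methoxy group, so compound 4 is the first to show a change at this position: a 13-fold lower number from compound 2 to compound 4 (1.10 log units; beyond the scatter). The nitro is therefore not needed for a low number here, and the larger (1-(methoxycarbonyl)ethyl)amino group, with its defined stereocentre, is tolerated. Nothing available explains this gain.

On these data alone, it remains open whether the gain comes from the amino nitrogen, the ester or the stereocentre. A plain amine, the free carboxylic acid or the opposite stereoisomer at this position would help separate these.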